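Cyclopentyl replacing pyridin-4-yl at the fused ring carbon

This account rests on a few compounds, and the source may have more. Where it says the series, first, only, none or still open, it means among the compounds named here.

Three compounds share one core and differ only in the group on an aromatic carbon of the fused system. Compound 1 `CCCn1c(=O)n(C)c(=O)c2[nH]c(-c3ccc(O)cc3)nc21` gives 2.54 nM in an assay on Cortex for displacement of a labelled ligand from adenosine receptor A1 (Rattus norvegicus) (a lower number here means a stronger inhibitor, a higher number a weaker inhibitor), compound 2 `CCCn1c(=O)n(C)c(=O)c2[nH]c(-c3cccs3)nc21` gives 8.93 nM, and compound 3 `CCCn1c(=O)n(C)c(=O)c2[nH]c(-c3ccncc3)nc21` gives 21.8 nM, the highest number of the three. The measured steps are a 3.5-fold higher number from compound 1 to compound 2 (0.55 log units; beyond the scatter), an 8.6-fold higher number from compound 1 to compound 3 (0.93 log units; beyond the scatter) and a 2.4-fold higher number from compound 2 to compound 3 (0.39 log units; beyond the scatter); each swaps one aromatic ring for another. Compound 4 `CCCn1c(=O)n(C)c(=O)c2[nH]c(C3CCCC3)nc21` instead carries cyclopentyl in place of pyridin-4-yl on an aromatic carbon. Going by the values given here, no measured step involves a non-aromatic ring, so these steps bear only loosely on it. Since every change away from pyridin-4-yl lowered the number, compound 4 is expected to give 2.5 nM, within 0.6 nM to 10 nM. This amounts to an expected step of an 8.7-fold lower number from compound 3 to compound 4 (0.94 log units; beyond the scatter).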

Compound 4, inhibition constant: 0.85 nM
Beside the measured number, compound 4's estimate is 2.9-fold (0.47 log units) above it, within the range that was stated.
By their numbers in this assay, from the lowest: compound 4; then compound 1; then compound 2; then compound 3.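

In this assay the steps of a 26-fold lower number from compound 3 to compound 4 (1.41 log units; beyond the scatter) and an 11-fold lower number from compound 2 to compound 4 (1.02 log units; beyond the scatter) and a 3.0-fold lower number from compound 1 to compound 4 (0.48 log units; beyond the scatter) put compound 4 lowest of the four, so this aromatic carbon takes a five-membered non-aromatic ring of carbon only and needs no aromatic ring to give a low number. Cyclopentyl also brings no hydrogen-bond acceptor or donor, so neither is required here for such a number. Nothing available explains why the non-aromatic ring does better.

The compounds shown leave open whether cyclopentyl's ring size matters, since cyclobutyl, cyclohexyl and an open chain such as pentyl are not among them.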